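Urotensin-2 receptor agonists: a saturated chain replaces a triple bond

This account rests on a few compounds, and the source may have more. Where it says the series, first, only, none or still open, it means among the compounds named here.

Measured so far:
compound 1, `CN(C)CCC(NC(=O)C#Cc1ccccc1)c1ccc2ccccc2c1`, 457 nM
compound 2, `COc1ccc(/C=C/C(=O)NC(CCN(C)C)c2ccc(C)cc2)cc1`, 2000 nM

In a functional assay on NIH3T3 cells for agonist activity at Urotensin-2 receptor (Homo sapiens), with a stated time of 5 days (on this read-out higher numbers stand for an effect only at larger amounts of compound and lower numbers for an effect already at smaller amounts), compound 1 gives the lower of the two numbers; the gap to compound 2 lies beyond the usual scatter. Compound 3, `CN(C)CCC(NC(=O)CCc1ccccc1)c1ccc2ccccc2c1`, has not been measured. It differs from compound 1 in one place: phenethyl in place of 2-phenylethynyl on a carbonyl carbon. For the measured compounds named here, no comparable step between measured compounds is known here, so the direction must be guessed. The step from compound 1 to compound 3 is expected to raise the number somewhat, a 2.6-fold higher number from compound 1 to compound 3 (0.42 log units; beyond the scatter). Compound 3 is therefore estimated at 1200 nM, within a range of 400 nM to 4000 nM.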

Compound 3, half-maximal effective concentration: 603 nM
Compound 3: the middle estimate sits 2.0-fold (0.30 log units) above what was measured; the range from low to high includes it.
By their numbers in this assay, from the lowest: compounds 1 and 3 (each within the scatter of the next); then compound 2.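

In this assay, putting phenethyl in place of 2-phenylethynyl on the carbonyl carbon gives a 1.3-fold higher number from compound 1 to compound 3 (0.12 log units; within the scatter), so the triple bond is not required for agonist activity at this position. The saturated chain, with the same count of heavy atoms and the same aromatic ring, serves within the scatter. Nothing measured here explains this outcome. Still open, as far as these compounds go, is how far this position tolerates other groups on the carbonyl carbon, such as a longer chain ending in phenyl, an amine or a carboxylic acid.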